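Working notes on the step from compound 2 to compound 3

The source may hold more compounds than are shown below. What is called first, only, known or untested is meant among the compounds shown, and "the series" means these compounds.

Measured so far:
compound 1 `Cc1cn(C2[Se][C@H](CO)[C@@H](O)[C@@H]2N=[N+]=[N-])c(=O)[nH]c1=O`; in a functional assay on SNU-638 cells (Homo sapiens) for cytotoxicity, read by sulforhodamine B assay (a lower number here means a stronger inhibitor, a higher number a weaker inhibitor), compound 1 gives > 100000 nM
compound 2 `O=c1ccn(C2[Se][C@H](CO)[C@@H](O)[C@@H]2O)c(=O)[nH]1`; in this assay compound 2 gives > 100000 nM

The value of compound 2 in this assay is a limit of the assay, not a number. The value of compound 1 is likewise a limit. Compound 2 therefore stands nowhere on a numbered scale: both results shown sit at the limit of > 100000 nM in this assay, at which 2 of the 2 values shown sit, and no ordering among the measured compounds can be read from them.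

Compound 3 `Cc1cn(C2[Se][C@H](CO)[C@@H](O)[C@@H]2O)c(=O)[nH]c1=O` is the next member. It differs from compound 2 by methyl in place of hydrogen on an aromatic carbon. Among the measured compounds shown here, no pair of measured compounds differs in one place, so no measured step gives the size of such a change here. With both shown results sitting at the limit, no step beyond the scatter is expected from compound 2 to compound 3 in this assay, and the expected step is a number no higher from compound 2 to compound 3 (the limit leaves the size open). Compound 3 is accordingly estimated at 100000 nM, within 30000 nM to 300000 nM, most likely reported again only as a limit.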

Compound 3, half-maximal inhibitory concentration: > 100000 nM
Compound 3 ended at the assay's limit; the forecaster's own chance of this, stated with the estimate: 85%; the middle value lies on the limit itself.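

In this assay compound 3 gives > 100000 nM, which is a limit of the assay and not a number. The steps from compound 2 and from compound 1 to compound 3 cannot be read, because every result sits at the same limit: the limit of > 100000 nM in this assay, at which 3 of the 3 values shown sit.

The compounds shown leave open what size of effect, if any, methyl in place of hydrogen on an aromatic carbon or hydroxy in place of azido on a saturated ring carbon has in this assay.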